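Series notes: amide-linked core, amine variation

The source may report more compounds than this note shows. Statements on the series, on what has been measured and on what is new or still open speak of the compounds shown alone.

Within the data shown here, compound 1 `CNC(=O)c1cc(Oc2ccc(Nc3nccc(N4CCCC4)n3)cc2)ccn1` is one of two compounds measured in a functional assay on HCT-116 cells (Homo sapiens) for inhibition, read by MTT assay, with a stated time of 72 h, tested at 20 uM; a lower number here means less inhibition, a higher number more inhibition at the concentration tested (going by the name of the read-out); in that assay compound 1 gives 66.4%. Compound 2 `CCN(CC)c1ccc(C(=O)Nc2ccc(Oc3ncnc4ccsc34)cc2)cc1` shows 37.9% in this assay, the lower of the two numbers and set beyond the scatter from compound 1. Compound 3 `CN(C)c1ccc(C(=O)Nc2ccc(Oc3ncnc4ccsc34)cc2)cc1` is not yet measured; its change from compound 2 is dimethylamino in place of diethylamino on an aromatic carbon. Among the measured compounds shown here, no measured step covers this change, so the expected step of a number 1.9 percentage points lower from compound 2 to compound 3 (within the scatter) is small, most likely within the scatter and of no clear direction. Compound 3 is thus expected to give 36% in this assay, between 16% and 56%.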

Compound 3, a percentage reported as inhibition, at one concentration (the size of the read-out at that concentration, not a potency): 53.9%
For compound 3 the middle estimate is 17.9 percentage points below the measured one, within the range that was stated.
By their numbers in this assay, from the lowest: compound 2; then compound 3; then compound 1.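

Dimethylamino in place of diethylamino, on an aromatic carbon para to a large group, gives a number 16 percentage points higher from compound 2 to compound 3 (beyond the scatter) in this assay and is the first measured step at this position. The substituents on this amine therefore do matter to the read-out at the one concentration tested, with the smaller of the two groups carrying the higher number. Nothing available explains this step.

Only these two groups are shown at this position, so it stays open whether the number keeps rising with a primary amine or holds with a ring such as morpholine.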